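Mirror image of compound 1 in the mannosidase assay

The source may hold more compounds than are shown below. What is called first, only, known or untested is meant among the compounds shown, and "the series" means these compounds.

Compound 1 `OC[C@]1(c2cccc(F)c2)NC[C@H](O)[C@H]1O` was tested in an assay on isolated protein for inhibition of alpha-mannosidase (Canavalia ensiformis), tested at 1000 uM (on this read-out lower numbers stand for less inhibition and higher numbers for more inhibition at the one concentration tested (going by the name of the read-out)), where compound 1 gives 0%. In the same this assay compound 2 `COc1ccc([C@]2(CO)NC[C@@H](O)[C@@H]2O)cc1` gives 0.2%. The two numbers sit together at the floor of the read-out and lie within the scatter of each other, so compound 1 stands alongside compound 2 at the bottom of the scale rather than apart from it. Compound 3 `OC[C@@]1(c2cccc(F)c2)NC[C@@H](O)[C@@H]1O` has not yet been measured in this assay. It differs from compound 1 as follows: the two compounds have the same atoms and bonds and differ only in configuration as drawn: 3 of 3 stereo elements differ (all stereocentres are inverted: mirror images); a stereocentre at a saturated ring carbon is drawn S in compound 1 and R in compound 3; a stereocentre at a saturated ring carbon is drawn S in compound 1 and R in compound 3; a stereocentre at a saturated ring carbon is drawn S in compound 1 and R in compound 3. With no measured step between any two of these compounds to draw on, and with compound 1 showing 0%, the expected step from compound 1 to compound 3 is a number 5 percentage points higher from compound 1 to compound 3 (within the scatter), a change not beyond the scatter and in no set direction. Compound 3 is therefore estimated at 5%, with a range from 0% to 30%.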

Compound 3, a percentage reported as inhibition, at one concentration (the size of the read-out at that concentration, not a potency): 0%
The estimate for compound 3 lay 5 percentage points above the measured number; measured number inside the range.
By their numbers in this assay, from the lowest: compounds 1, 3 and 2 (each within the scatter of the next).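

Inverting all three stereocentres at once gives no change at the digits printed from compound 1 to compound 3 (within the scatter) in this assay, so for this pair the earlier compounds' place at the floor of the read-out holds for both mirror forms. Configuration is the only thing that varies in this comparison: the fact that compounds 1 and 3 differ only in the configuration as drawn. The pair therefore shows that the full inversion does not separate the two forms in this read-out, but with both at the floor it cannot show how much configuration would count in a compound that registers inhibition.

On these data alone, whether inverting one stereocentre alone would give a different reading stays open, since here all three change together. Also open, as far as these compounds go, is whether an amine or a carboxylic acid in place of the fluorine would lift the read-out off the floor in either mirror form.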